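Naphthalen-1-yl in place of 4-methoxyphenyl: working notes

The source may hold more compounds than are shown below. What is called first, only, known or untested is meant among the compounds shown, and "the series" means these compounds.

Compound 1 `CCNc1cc(-c2ccc(NC(=O)Nc3ccc(C)cc3)cc2C(F)(F)F)ccn1`: 27100 nM
Compound 2 `CCNc1cc(-c2ccc(NC(=O)Nc3ccc(OC)cc3)cc2C(F)(F)F)ccn1`: 17600 nM

All values come from a functional assay on BT-483 cells (Homo sapiens) for cytotoxicity, read by MTT assay, with a stated time of 24 h; a higher number here means a weaker inhibitor, a lower number a stronger inhibitor. Among the compounds with values here, the series so far holds one measured step, a 1.5-fold lower number from compound 1 to compound 2 (0.19 log units; within the scatter), with methoxy in place of methyl on an aromatic carbon. On these numbers, compound 2 at 17600 nM cannot be separated from compound 1, and both values sit in the same high range.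

Next is compound 3 `CCNc1cc(-c2ccc(NC(=O)Nc3cccc4ccccc34)cc2C(F)(F)F)ccn1`, which departs from compound 2 as follows: naphthalen-1-yl in place of 4-methoxyphenyl on an amide-type nitrogen. In words, naphthalen-1-yl stands in place of 4-methoxyphenyl on an amide-type nitrogen.

Within the data shown here, this is a larger change than the one measured step, and no measured compound carries naphthalen-1-yl, so that step is only a weak guide. Among the measured compounds shown here, with a 1.5-fold lower number from compound 1 to compound 2 (0.19 log units; within the scatter) as the sole precedent, no shift beyond the scatter is expected in this assay, and no direction can be argued with confidence. The expected step is a 1.1-fold lower number from compound 2 to compound 3 (0.04 log units; within the scatter). Compound 3 is estimated at 16000 nM, with an expected range from 7000 nM to 36000 nM.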

Compound 3, half-maximal inhibitory concentration: > 30000 nM
Compound 3: only a limit was reported (the forecaster's own chance of this, stated with the estimate: 10%); middle value at least 1.8-fold (0.27 log units) from the limit.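

In this assay compound 3 is reported only as a limit of the assay and not as a number: the limit of > 30000 nM in this assay, at which 1 of the 3 values shown sits. The change on the amide-type nitrogen reads as an at least 1.7-fold higher number from compound 2 to compound 3 (0.23 log units; that floor lies within the scatter), and against the methyl analogue as an at least 1.1-fold higher number from compound 1 to compound 3 (0.04 log units; that floor lies within the scatter), so neither floor separates naphthalen-1-yl from the 4-methoxyphenyl or 4-methylphenyl groups, although the true gaps may be larger. The earlier step only exchanged methyl for methoxy on an aromatic carbon with the phenyl kept, whereas this result replaces the whole aryl group on that nitrogen, and the limit shows that naphthalen-1-yl brings no lower number in this assay.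

As far as these compounds go, how far the number for compound 3 lies past its limit stays open, and with it the true size of both steps. Also open, from the compounds shown here alone, is whether a phenyl carrying a carboxylic acid or a dimethylamino group on the same amide-type nitrogen would give a number clearly separated from those of compound 1 and compound 2.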